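The compounds below may be only part of what the source reports. "The series", "measured", "known", "first", "only" and "open" are said of these compounds alone.

In a functional assay on HepG2 cells (Homo sapiens) for antiproliferative activity, read by MTT assay, with a stated time of 48 h (a higher number here means a weaker inhibitor, a lower number a stronger inhibitor), compound 1 `O=C(Nc1ccc(Cl)cc1)Nc1cccc(CNc2nccnc2Cl)c1` gives 8350 nM and compound 2 `O=C(Nc1ccc(C(F)(F)F)cc1)Nc1cccc(CNc2nccnc2Cl)c1` gives 5050 nM. Among the compounds with values here, these are the only two measurements so far, and they lie within the usual scatter of each other, so compound 2 cannot be ranked against compound 1. Compound 3 `Cc1ccc(NC(=O)Nc2cccc(CNc3nccnc3Cl)c2)cc1` changes a single group of compound 2: methyl in place of trifluoromethyl on an aromatic carbon. Within the data shown here, only one measured step bears on this change, and it concerns the same aromatic carbon: trifluoromethyl in place of chloro gave a 1.7-fold lower number from compound 1 to compound 2 (0.22 log units; within the scatter). That small step stays within the scatter, and no compound with methyl at this carbon has been measured yet, so the data offer no reason to expect a real shift in either direction. The expected change is a 1.5-fold higher number from compound 2 to compound 3 (0.17 log units; within the scatter), which would not go beyond the scatter. Compound 3 is estimated at 7500 nM, with a likely range from 3500 nM to 17000 nM.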

Compound 3, half-maximal inhibitory concentration: 11500 nM
Compound 3: the middle estimate sits 1.5-fold (0.19 log units) below what was measured; measured number inside the range.
By their numbers in this assay, from the lowest: compounds 2, 1 and 3 (each within the scatter of the next, the first and the last beyond it).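

In this assay, within the data shown here, methyl in place of trifluoromethyl gives a 2.3-fold higher number from compound 2 to compound 3 (0.36 log units; beyond the scatter) and is the first step to pass beyond the scatter, so the group on this aromatic carbon, para to a large group, can change the number, though only modestly. Methyl in place of chloro gives a 1.4-fold higher number from compound 1 to compound 3 (0.14 log units; within the scatter) and stays within the scatter, so compound 1 and compound 3 cannot be ranked and only the trifluoromethyl and methyl compounds are separated. Nothing available here accounts for that separation.

On these data alone, it remains open how an amine, a methoxy group or a longer chain such as ethyl would behave on this carbon. As far as these compounds go, whether the same methyl change would give a similar step on a different core also remains open.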